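A few compounds are considered here, and "the series" means these few. Any claim that something is new, unique, unknown or untested is made for them only; others in the source may bear on it.

Measured so far, in a functional assay on MDA-MB-231 cells (Homo sapiens) for cytotoxicity, read by MTT assay, with a stated time of 48 h; a higher number here means a weaker inhibitor, a lower number a stronger inhibitor:
- compound 1 `COc1ccc(C(=O)CSC(=S)Nc2cc(OC)c(OC)c(OC)c2)cc1`: 16.4 ug/mL
- compound 2 `COc1cc(N2C(=S)SCC2(O)c2ccc(Cl)cc2Cl)cc(OC)c1OC`: 14.5 ug/mL
- compound 3 `COc1cc(-n2c(-c3ccc(Cl)cc3Cl)csc2=S)cc(OC)c1OC`: 49 ug/mL

Compound 3 gives the highest number of the three. Its nearest neighbour is compound 1, whose number is lower by a margin beyond the usual scatter; compound 2 lies further still below, also beyond the scatter. Compound 3 is therefore the weakest inhibitor of the set as measured.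

The next compound, compound 4 `COc1ccc(-c2csc(=S)n2-c2cc(OC)c(OC)c(OC)c2)cc1`, keeps the core of compound 3 and changes one place: 4-methoxyphenyl in place of 2,4-dichlorophenyl on an aromatic carbon. For the measured compounds named here, no measured pair shows this exchange, so its size is unknown. Nothing in the three numbers points to a large shift; a step of modest size is expected, most likely toward lower numbers, and possibly none beyond the scatter. Compound 4 is estimated at 32 ug/mL, within 14 ug/mL to 75 ug/mL, an expected step of a 1.5-fold lower number from compound 3 to compound 4 (0.19 log units; within the scatter).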

Compound 4, half-maximal inhibitory concentration: 53.8 ug/mL
Compound 4: the middle estimate sits 1.7-fold (0.23 log units) below what was measured; the measured number falls inside the stated range.
By their numbers in this assay, from the lowest: compounds 2 and 1 (each within the scatter of the next); then compounds 3 and 4 (each within the scatter of the next).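

In this assay the exchange of 2,4-dichlorophenyl for 4-methoxyphenyl, on the aromatic carbon next to the ring nitrogen, gives a 1.1-fold higher number from compound 3 to compound 4 (0.04 log units; within the scatter) and so leaves the number unmoved within the scatter. At this position, these two aryl groups are therefore not told apart by this read-out. No measured property in hand bears on this result.

Still open, going by these compounds, is whether an amine or a carboxylic acid on the phenyl ring would move the number beyond the scatter. Also open, on these data alone, is whether a plain methyl in place of the whole aryl group would do so.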